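Trimming the aryl group: from dichlorophenyl to phenyl

The source may hold more compounds than are shown below. What is called first, only, known or untested is meant among the compounds shown, and "the series" means these compounds.

Three acylguanidines sharing one core have been measured in a functional assay for inhibition of sodium/hydrogen exchanger (Oryctolagus cuniculus); a lower number here means a stronger inhibitor, a higher number a weaker inhibitor. Compound 1 `Cc1cc(C)c(S(C)(=O)=O)cc1C(=O)N=C(N)N` gives 11 nM. Compound 2 `CCCCCc1cc(C)c(C(=O)N=C(N)N)cc1S(C)(=O)=O`, carrying a pentyl chain in place of the methyl, gives 27 nM, a shift recorded as a 2.5-fold higher number from compound 1 to compound 2 (0.39 log units; beyond the scatter). Compound 3 `Cc1cc(-c2cc(Cl)cc(Cl)c2)c(S(C)(=O)=O)cc1C(=O)N=C(N)N`, bearing a 3,5-dichlorophenyl group on the same aromatic carbon, gives 130 nM and stands highest of the three numbers; the step of a 12-fold higher number from compound 1 to compound 3 (1.07 log units; beyond the scatter) is large, and the step of a 4.8-fold higher number from compound 2 to compound 3 (0.68 log units; beyond the scatter) is modest.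

Compound 4 `Cc1cc(-c2ccccc2)c(S(C)(=O)=O)cc1C(=O)N=C(N)N` is the next member: phenyl in place of 3,5-dichlorophenyl on an aromatic carbon. Among the compounds with values here, two measured steps bear on this change. The large loss seen in a 12-fold higher number from compound 1 to compound 3 (1.07 log units; beyond the scatter) and the smaller loss seen in a 4.8-fold higher number from compound 2 to compound 3 (0.68 log units; beyond the scatter) both show that the 3,5-dichlorophenyl group sits at the weak end of this short series, and the phenyl group is intermediate between methyl and 3,5-dichlorophenyl in what it brings. A modest step toward a lower number in this assay is therefore expected for compound 4, estimated as a 2.2-fold lower number from compound 3 to compound 4 (0.34 log units; beyond the scatter). Compound 4 is expected to give about 60 nM in this assay, within a range of 25 nM to 150 nM.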

Compound 4, half-maximal inhibitory concentration: 19 nM
For compound 4 the middle estimate is 3.2-fold (0.50 log units) above the measured one, outside the stated range (below it).
By their numbers in this assay, from the lowest: compounds 1, 4 and 2 (each within the scatter of the next, the first and the last beyond it); then compound 3.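

Within this assay, the step of a 6.8-fold lower number from compound 3 to compound 4 (0.84 log units; beyond the scatter) ties the poor result of compound 3 to the two chlorine atoms of the 3,5-dichlorophenyl group, not to the mere presence of an aromatic ring on this carbon, ortho to the methylsulfonyl group. The plain phenyl is well accepted here: the step of a 1.7-fold higher number from compound 1 to compound 4 (0.24 log units; within the scatter) and the step of a 1.4-fold lower number from compound 2 to compound 4 (0.15 log units; within the scatter) both lie within the scatter, so compound 4 cannot be separated from either compound 1 or compound 2, even though those two stand apart from each other. Of the four groups at this position, only the 3,5-dichlorophenyl stands clearly apart from all the others, and it gives the weakest inhibitor of the set.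

As far as these compounds go, it remains open whether a single chlorine would carry the same loss, and whether a fluorine or a methoxy group on the phenyl ring, or a saturated ring such as cyclohexyl, would behave like phenyl or like 3,5-dichlorophenyl. The data shown offer no independent measurement that accounts for the gap between compound 3 and compound 4.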